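This account rests on a few compounds, and the source may have more. Where it says the series, first, only, none or still open, it means among the compounds named here.

Measured so far in a physicochemical assay for solubility, in phosphate buffer, measured as kinetic solubility, at pH 7.4; on this read-out higher numbers stand for higher solubility and lower numbers for lower solubility:

compound 1 `Cc1ccccc1-c1nc(CN2CCC(C(=O)NCCCN3CCC(C(C)C)CC3)CC2)c(C)o1` gives > 71 ug/mL (a limit)
compound 2 `Cc1ccccc1-c1nc(CN2CCC(C(=O)NCCCN3CCCC(CC(C)C)C3)CC2)c(C)o1` gives 54.9 ug/mL
compound 3 `Cc1oc(-c2c(Br)cccc2Br)nc1CN1CCC(C(=O)NCCCN2C[C@H](C)C[C@H](C)C2)CC1` gives 62.4 ug/mL

The entry for compound 1 is a limit of the assay and not a number. Of the two true numbers, compound 3 at 62.4 ug/mL and compound 2 at 54.9 ug/mL lie within the scatter of each other.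

Compound 4 `CCc1ccccc1-c1nc(CN2CCC(C(=O)NCCCN3C[C@H](C)C[C@H](C)C3)CC2)c(C)o1` differs from compound 3 in one place: 2-ethylphenyl in place of 2,6-dibromophenyl on an aromatic carbon. Going by the values given here, no measured step touches this group. Among the compounds with values here, the only step available, an at least 1.2-fold lower number from compound 1 to compound 2 (0.11 log units; that floor lies within the scatter), lies elsewhere in the molecule, on a saturated chain carbon, and its floor lies within the scatter, so it gives no size for this exchange. Compound 2 and compound 3 do carry different groups at this place, and they differ elsewhere as well, yet their two numbers stay within the scatter. A step beyond the scatter in this assay is therefore not expected, in either direction. The expected change is a 1.0-fold lower number from compound 3 to compound 4 (0.02 log units; within the scatter) and no more than that. For compound 4 the estimated value is 60 ug/mL, with an expected range from 30 ug/mL to 85 ug/mL.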

Compound 4, solubility: 55.9 ug/mL
Beside the measured number, compound 4's estimate is 1.1-fold (0.03 log units) above it; measured number inside the range.
By their numbers in this assay, from the lowest: compounds 2, 4 and 3 (each within the scatter of the next). At a limit, above all of these: compound 1.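

The exchange of 2,6-dibromophenyl for 2-ethylphenyl, on an aromatic carbon of a five-membered aromatic ring with 1 nitrogen and 1 oxygen, gives in this assay a 1.1-fold lower number from compound 3 to compound 4 (0.05 log units; within the scatter). Going by these compounds alone, this is the first view of this position with the rest of the molecule held fixed, since compound 2 and compound 3 carry different groups here but also differ elsewhere. The two groups leaving and entering have the same count of heavy atoms and the same single aromatic ring of carbon only, and with the two bromine atoms gone and an ethyl group in their place, this assay does not tell compound 3 and compound 4 apart, and compound 1 alone stands at a limit, which is not a number: the limit of > 71 ug/mL in this assay, at which 1 of the 4 values shown sits.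

What the compounds shown leave open is whether this place stays as flat in this assay once the phenyl ring carries something other than halogen or alkyl, such as an amine or a carboxylic acid, or gives way to a pyridine ring. Both groups compared here have no hydrogen-bond donors, no hydrogen-bond acceptors and no net charge, so this single step says nothing about groups that have them.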